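The source may hold more compounds than are shown below. What is called first, only, known or untested is meant among the compounds shown, and "the series" means these compounds.

Measured so far:
- compound 1, `O=C(CSc1nnc(-c2ccncc2)o1)N/N=C/c1ccc([N+](=O)[O-])cc1`: 25800 nM
- compound 2, `O=C(CSc1nnc(-c2ccncc2)o1)N/N=C/c1ccccc1[N+](=O)[O-]`: 30700 nM

The two measured compounds share a common core and differ only in the group attached to the carbon with a double bond to nitrogen. In a functional assay on SW 1116 cells (Homo sapiens) for cytotoxicity, read by MTT assay, with a stated time of 48 h (a higher number here means a weaker inhibitor, a lower number a stronger inhibitor), compound 1 gives 25800 nM and compound 2 gives 30700 nM; the step of a 1.2-fold higher number from compound 1 to compound 2 (0.08 log units; within the scatter) is within the scatter, so the two numbers cannot be told apart. Compound 1 has the lowest number of the two, but only by a margin that repeated measurements would blur.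

Compound 3, `O=C(CSc1nnc(-c2ccncc2)o1)N/N=C/c1cccs1`, is the next compound to be measured. It differs from compound 1 as follows: thiophen-2-yl in place of 4-nitrophenyl on a carbon with a double bond to nitrogen. For the measured compounds named here, no measured step shows this change; the only known step swaps one nitrophenyl for another and does not involve a thiophene, so it bears on this change only loosely. Without a relevant step, the expected step of a 1.1-fold higher number from compound 1 to compound 3 (0.04 log units; within the scatter) is set to none beyond the scatter, with a wide range to reflect the lack of information.

Compound 3 is therefore estimated at 28000 nM, with a range from 9000 nM to 90000 nM.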

Compound 3, half-maximal inhibitory concentration: 24900 nM
Estimate against measurement, compound 3: 1.1-fold (0.05 log units) above, and the stated range covers the measured number.
By their numbers in this assay, from the lowest: compounds 3, 1 and 2 (each within the scatter of the next).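

In this assay the earlier pair only moved a nitro group around a phenyl ring, whereas this change replaces the whole ring on the carbon with a double bond to nitrogen. A six-membered aromatic ring of carbon only, with its nitro group, gives way to a five-membered aromatic ring with 1 hetero atom, a sulfur, and the group falls from 9 heavy atoms to 5. Even so, neither new step can be told from the scatter (a 1.0-fold lower number from compound 1 to compound 3 (0.02 log units; within the scatter); a 1.2-fold lower number from compound 2 to compound 3 (0.09 log units; within the scatter)), so among these three compounds the number at this position does not respond to the nitro group or to the size of the ring. No measurement available here bears on this result.

All three groups on this carbon are aromatic rings, so the compounds shown leave open whether anything placed here can move the number beyond the scatter. An amine, a carboxylic acid or a longer carbon chain in the same place would test that, and a plain phenyl ring would separate the ring itself from its nitro group.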